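A few compounds are considered here, and "the series" means these few. Any claim that something is new, unique, unknown or untested is made for them only; others in the source may bear on it.

In an ADME assay, at pH 5 (a lower number here means that the compound disappears faster, a higher number that the compound lasts longer), compound 3 (`COc1cnc(C[S+]([O-])c2nc3cc(OC(F)(F)C(F)F)ccc3[nH]2)cc1OC`) gives 2.9 h. This is within the scatter of compound 2 (`COc1ccnc(C[S+]([O-])c2nc3cc(OC(F)(F)C(F)F)ccc3[nH]2)c1OC`) at 3.6 h. Compound 1 (`COc1ccnc(C[S+]([O-])c2nc3cc(OC(F)F)ccc3[nH]2)c1`) gives 0.8 h. Compound 3 stands higher than compound 1, and that gap lies beyond the scatter. Compound 4 (`COc1ccnc(C[S+]([O-])c2nc3cc(OC(F)(F)C(F)F)ccc3[nH]2)c1`) differs from compound 3 by hydrogen in place of methoxy on an aromatic carbon. Among the compounds with values here, no measured pair isolates this change. The expectation rests on compound 1, which also carries a single methoxy on the six-membered aromatic ring with 1 nitrogen and stands at 0.8 h. A drop beyond the scatter in this assay is therefore expected, with an estimated step of a 2.4-fold lower number from compound 3 to compound 4 (0.38 log units; beyond the scatter). For compound 4 the estimated half-life is 1.2 h, with an expected range of 0.6 h to 2.4 h.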

Compound 4, half-life: 0.8 h
Beside the measured number, compound 4's estimate is 1.5-fold (0.18 log units) above it; low and high end bracket the measured number.
By their numbers in this assay, from the lowest: compounds 1 and 4 (each within the scatter of the next); then compounds 3 and 2 (each within the scatter of the next).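

In this assay, hydrogen in place of methoxy on the six-membered aromatic ring with 1 nitrogen shortens the half-life, with a 3.6-fold lower number from compound 3 to compound 4 (0.56 log units; beyond the scatter) and a 4.5-fold lower number from compound 2 to compound 4 (0.65 log units; beyond the scatter). Difluoromethyl in place of hydrogen on the chain carbon bound to two fluorine atoms and an oxygen gives no change at the digits printed from compound 1 to compound 4 (within the scatter), so among these four compounds the second methoxy, not the chain, tracks the half-life. Nothing available explains these steps. As far as these compounds go, whether an ethoxy group, a chlorine atom or an amine could stand in for this methoxy remains open.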